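The source may report more compounds than this note shows. Statements on the series, on what has been measured and on what is new or still open speak of the compounds shown alone.

Measured compounds in a functional assay on the whole organism (strain Swiss) with Mus musculus as the target, in the maximal electroshock model, with a stated time of 2 h, at a dose of 100 mg/kg by the intraperitoneal route; a higher number here means a stronger effect of the compound at the dose given, a lower number a weaker effect:
- compound 1 `CCC(C(=O)N1CCN(c2ccccc2F)CC1)N1C(=O)CCC1=O`: 0%
- compound 2 `CC(C(=O)N1CCN(c2cccc(Cl)c2)CC1)N1C(=O)CCC1=O`: 0%

Compound 2 stands level with compound 1 at the digits shown; the two values are the same, and no change within the scatter can be read between them. Both compounds share the same core, differ in the substituent on the six-membered aromatic ring of carbon only and in the chain on the carbon that carries the amide carbonyl, and neither shows any effect in this assay at the dose given.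

Compound 3 `CC(C(=O)N1CCN(c2cccc(F)c2)CC1)N1C(=O)CCC1=O` has not been measured. It differs from compound 2 in one place:

fluoro in place of chloro on an aromatic carbon

Cut one bond further out, the change reads 3-chlorophenyl to 3-fluorophenyl. Among the measured compounds shown here, no step between measured compounds exists for this exchange. Compound 1 already carries a fluoro on its aromatic ring and gives no effect, and compound 2 with chloro gives no effect, so nothing in the numbers points to a gain. The step of no change at the digits printed from compound 2 to compound 3 (within the scatter) is expected to be none beyond the scatter. Compound 3 is estimated at 0%, with a range from 0% to 15%.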

Compound 3, a percentage reported as activity, at one dose (the size of the read-out at that dose, not a potency): 0%
Estimate against measurement, compound 3: no gap at the digits printed, within the range that was stated.
By their numbers in this assay, from the lowest: compounds 1, 2 and 3 (each within the scatter of the next).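

In this assay, among the compounds shown here, fluoro in place of chloro on an aromatic carbon gives no change at the digits printed from compound 2 to compound 3 (within the scatter), and this is the only step that isolates a single change. For the compounds shown here, since compound 2 and compound 3 both show no effect at the dose given, the step shows only that this exchange, 3-chlorophenyl to 3-fluorophenyl, does not bring out an effect; with no effect on either side, it cannot rank the two halogens at this position. No measured evidence bears on this result.

Still open, going by these compounds, is whether a different group on this aromatic carbon, such as trifluoromethyl or methoxy, would give any effect in this assay. Also open, on these data alone, is whether a longer chain on the carbon that carries the amide carbonyl would change the read-out, and whether the exchange of chloro for fluoro would then make a measurable difference.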